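Bromo in place of methyl on compound 2

This account rests on a few compounds, and the source may have more. Where it says the series, first, only, none or still open, it means among the compounds named here.

For the measured compounds named here, in an ADME assay on J774.A1 cells (Mus musculus) for cytotoxicity, read by MTT assay, with a stated time of 72 h (a higher number here means that more compound is tolerated, a lower number that less compound is tolerated), compound 1 `COC(=O)C1=C(C)N(c2ccc(C)cc2)C(C)=C(C(=O)OC)C1[C@@H]1O[C@H]2OC(C)(C)O[C@H]2[C@@H]1OCc1ccccc1` gives 7.66 ug/mL, while compound 2 `COC(=O)C1=C(C)N(c2ccc(C)cc2)C(C)=C(C(=O)OC)C1[C@@H]1O[C@H]2OC(C)(C)O[C@H]2[C@@H]1OC` gives 33.1 ug/mL, the higher of the two numbers so far. Compound 3 `COC(=O)C1=C(C)N(c2ccc(Br)cc2)C(C)=C(C(=O)OC)C1[C@@H]1O[C@H]2OC(C)(C)O[C@H]2[C@@H]1OC` differs from compound 2 at one place, with bromo in place of methyl on an aromatic carbon, para to a large group: bromo in place of methyl on an aromatic carbon. Going by the values given here, the only measured step, a 4.3-fold higher number from compound 1 to compound 2 (0.64 log units; beyond the scatter), comes from hydrogen in place of phenyl on a saturated chain carbon bound to an oxygen, a different place in the structure. Among the compounds with values here, it therefore bears on this change only indirectly, and no measured step involves the 4-methylphenyl group. No step beyond the scatter is expected in this assay. The estimated step is a 1.1-fold lower number from compound 2 to compound 3 (0.04 log units; within the scatter). Compound 3 is estimated at 30 ug/mL, with an expected range from 14 ug/mL to 65 ug/mL.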

Compound 3, half-maximal cytotoxic concentration: 48.5 ug/mL
Compound 3: the middle estimate sits 1.6-fold (0.21 log units) below what was measured, and the stated range covers the measured number.
By their numbers in this assay, from the lowest: compound 1; then compounds 2 and 3 (each within the scatter of the next).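

In this assay, for the compounds shown here, the change from 4-methylphenyl to 4-bromophenyl gives a 1.5-fold higher number from compound 2 to compound 3 (0.17 log units; within the scatter) and so stays within the scatter, the first reading at this aromatic carbon, para to a large group. Here bromo and methyl cannot be told apart, whereas the only step beyond the scatter remains a 4.3-fold higher number from compound 1 to compound 2 (0.64 log units; beyond the scatter) at the other place in the structure. No measurement at hand explains either step.

On these data alone, what remains open is whether an amine or a carboxylic acid on this same aromatic carbon would also stay within the scatter of compound 2. As far as these compounds go, it is also open whether bromo would give a similar result with the phenyl-bearing chain of compound 1 in place of the methyl on the oxygen.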